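Changing the Group on an Amide-Type Nitrogen

The source may hold more compounds than are shown below. What is called first, only, known or untested is meant among the compounds shown, and "the series" means these compounds.

Measured in a functional assay on HT-29 cells (Homo sapiens) for cytotoxicity, read by MTT assay, with a stated time of 72 h; on this read-out higher numbers stand for weaker inhibition and lower numbers for stronger inhibition:
- Compound 1 `O=C(CN1CCN(c2nnc(Cc3ccncc3)c3ccccc23)CC1)Nc1ccc(F)c(C(F)(F)F)c1`: 1110 nM
- Compound 2 `Cc1ccccc1NC(=O)CN1CCN(c2nnc(Cc3ccncc3)c3ccccc23)CC1`: 15000 nM

Compound 2 has the higher of these two numbers, which makes it the weaker inhibitor of the pair. The next compound, compound 3 `O=C(CN1CCN(c2nnc(Cc3ccncc3)c3ccccc23)CC1)Nc1ccc(F)c(F)c1`, keeps the shared core and alters a single group: 3,4-difluorophenyl in place of 2-methylphenyl on an amide-type nitrogen. Here 3,4-difluorophenyl takes the place of 2-methylphenyl on an amide-type nitrogen.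

For the measured compounds named here, only one measured step bears on this change, and it sits at the same place: a 14-fold higher number from compound 1 to compound 2 (1.13 log units; beyond the scatter). This large step shows that the group on this nitrogen can shift the number strongly. The case for expecting a lower number rests on compound 1, whose phenyl ring also carries fluorine and which gives 1110 nM. The entering group has no trifluoromethyl, however, and a single step is thin evidence, so only part of that gap is expected to be recovered.

The expected change in this assay is a 5.0-fold lower number from compound 2 to compound 3 (0.70 log units; beyond the scatter), an estimate pointing toward stronger inhibition. For compound 3 the estimated value is 3000 nM, with an expected range from 900 nM to 10000 nM.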

Compound 3, half-maximal inhibitory concentration: 2320 nM
Compound 3: the middle estimate sits 1.3-fold (0.11 log units) above what was measured; the range from low to high includes it.
By their numbers in this assay, from the lowest: compound 1; then compound 3; then compound 2.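

For the compounds shown here, two rings carrying fluorine now sit on the amide-type nitrogen, and in this assay both give lower numbers than the 2-methylphenyl ring of compound 2, so this position responds to more than the one swap seen earlier. The move to 3,4-difluorophenyl gives a 6.5-fold lower number from compound 2 to compound 3 (0.81 log units; beyond the scatter), and this step is larger than the one that remains up to the trifluoromethyl-bearing ring of compound 1, which is a 2.1-fold higher number from compound 1 to compound 3 (0.32 log units; beyond the scatter). Trifluoromethyl is therefore not required for most of the gain among these three compounds, although fluoro in its place still costs a modest amount of inhibition, and nothing here gives a measured reason for either step.

The step from compound 2 to compound 3 removes the methyl and adds two fluorines on different ring positions at once, so it cannot show which of these changes matters, or whether the methyl raises the number or the fluorines lower it. Plain phenyl and 4-fluorophenyl on the same nitrogen would help separate these effects, while a ring carrying a carboxylic acid or an amine would test quite different groups at this position.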